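This account rests on a few compounds, and the source may have more. Where it says the series, first, only, none or still open, it means among the compounds named here.

Measured so far:
compound 1 `Cc1cccc(-c2ncnc3c2cnn3CCN2CCCCC2)c1`, an assay on HEK293 cells for displacement of a labelled ligand from Sigma non-opioid intracellular receptor 1 (Homo sapiens), read by scintillation counting, with a stated time of 120 min (on this read-out lower numbers stand for stronger inhibition and higher numbers for weaker inhibition), 82 nM
compound 2 `Cc1ccncc1-c1ncnc2c1cnn2CCN1CCCCC1`, this assay 707 nM

Compound 2 gives the highest of the two numbers in this assay; its nearest neighbour is compound 1, and the step of an 8.6-fold higher number from compound 1 to compound 2 (0.94 log units; beyond the scatter) lies beyond the scatter.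

Compound 3 `Cn1nccc1-c1ncnc2c1cnn2CCN1CCCCC1` differs from compound 2 in one place: 1-methyl-1H-pyrazol-5-yl in place of 4-methylpyridin-3-yl on an aromatic carbon.

Among the compounds with values here, only one measured step bears on this change, an 8.6-fold higher number from compound 1 to compound 2 (0.94 log units; beyond the scatter), which shows that swapping the aryl group at this position can move the number by a modest amount. Within the data shown here, the new group has no measured precedent, so the direction of the coming step is uncertain. The expectation for this assay is a step no larger than the one already seen, a 1.4-fold higher number from compound 2 to compound 3 (0.15 log units; within the scatter), most likely toward a weaker or similar number. Compound 3 is therefore expected to give about 1000 nM, within a range of 250 nM to 4000 nM.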

Compound 3, inhibition constant: 41 nM
Beside the measured number, compound 3's estimate is 24-fold (1.39 log units) above it; measured number below the stated range.
By their numbers in this assay, from the lowest: compounds 3 and 1 (each within the scatter of the next); then compound 2.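

In this assay the exchange of 4-methylpyridin-3-yl for 1-methyl-1H-pyrazol-5-yl gives a 17-fold lower number from compound 2 to compound 3 (1.24 log units; beyond the scatter) and shows that the higher number of compound 2 is not a general outcome of placing a heteroaromatic ring at this position. Against 3-methylphenyl the same group gives a 2.0-fold lower number from compound 1 to compound 3 (0.30 log units; within the scatter) so the five-membered aromatic ring with 2 hetero atoms serves here as well as the phenyl ring does, and ring nitrogen alone does not track the number, with compound 3 going against any such link. No measurement shown accounts for the gap between compound 2 and compound 3.

The compounds shown leave open what the methyl contributes on either heteroaromatic ring, which the unsubstituted 1H-pyrazol-5-yl and pyridin-3-yl groups would address. Also open, as far as these compounds go, is how an isomeric 1-methyl-1H-pyrazol-4-yl group would compare at this position.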